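Saturating one chain double bond: from compound 3 to compound 4

The source may hold more compounds than are shown below. What is called first, only, known or untested is meant among the compounds shown, and "the series" means these compounds.

The three measured compounds are esters that were tested in an assay on cerebellum for inhibition of Monoglyceride lipase (Rattus norvegicus); on this read-out higher numbers stand for weaker inhibition and lower numbers for stronger inhibition. Compound 1, `CCCCC/C=C\C/C=C\C/C=C\C/C=C\CCCC(=O)OCC1COC(C)(C)O1`, gives 45000 nM. Compound 2, `O=C(OCC1CCCCO1)c1ccccc1`, gives 3000 nM. Compound 3, `CC/C=C\C/C=C\C/C=C\CCCCCCCC(=O)OCC1CCCCO1`, gives 23000 nM, which stands second highest of the three numbers; its nearest neighbour is compound 1, whose number lies within the usual scatter of compound 3, while the gap down to compound 2 is beyond the scatter.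

Compound 4, `CCCCC/C=C\C/C=C\CCCCCCCC(=O)OCC1CCCCO1`, is not yet measured. It differs from compound 3 in a single place: butyl in place of but-1-en-1-yl on a saturated chain carbon bound to a double-bonded chain carbon. For the measured compounds named here, no measured pair shows this change, so the size of its effect is unknown. Since the change neither adds nor removes a donor or acceptor and keeps the chain length, the estimate for compound 4 is a step of a 1.1-fold higher number from compound 3 to compound 4 (0.04 log units; within the scatter) that stays within the scatter, giving an expected value of 25000 nM, with a range from 10000 nM to 60000 nM.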

Compound 4, half-maximal inhibitory concentration: 73000 nM
Compound 4: the middle estimate sits 2.9-fold (0.47 log units) below what was measured, outside the stated range (above it).
By their numbers in this assay, from the lowest: compound 2; then compounds 3, 1 and 4 (each within the scatter of the next, the first and the last beyond it).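

In this assay, for the compounds shown here, butyl in place of but-1-en-1-yl on a saturated chain carbon bound to a double-bonded chain carbon gives a 3.2-fold higher number from compound 3 to compound 4 (0.50 log units; beyond the scatter) and thus weaker inhibition, the first single change in this set seen to move the number beyond the scatter. The two groups hold the same count of heavy atoms and differ only in the one double bond, so this chain position responds to that double bond alone, even though the compounds are long-chain esters whose numbers otherwise lie close together. Nothing at hand explains the direction of the step.

As far as these compounds go, whether a fully saturated chain or a longer chain would extend the step remains open. So does whether the same change would act alike with the core of compound 1, or with an amide in place of the ester.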